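Side-chain variation in a bis-aryl series: compound 3 projected

A few compounds are considered here, and "the series" means these few. Any claim that something is new, unique, unknown or untested is made for them only; others in the source may bear on it.

Measured so far:
- compound 1 `COC[C@H](C(C)C)C(c1ccc(O)c(OC)c1)c1ccc(O)c(OC)c1` gives 72000 nM in a functional assay on HL-60 cells (Homo sapiens) for cytotoxicity, read by WST assay, with a stated time of 48 h; a higher number here means a weaker inhibitor, a lower number a stronger inhibitor
- compound 2 `COc1cc(C(c2ccc(O)c(OC)c2)[C@H](C)[C@@H](C)CO)ccc1O` gives > 100000 nM in this assay
- compound 3 `COc1cc(C(c2ccc(O)c(OC)c2)[C@@H](CF)C(C)C)ccc1O` is not yet measured in this assay

Compound 2 stands at a limit of this assay, not at a number; its reading of > 100000 nM is shown as the limit of > 100000 nM in this assay, at which 1 of the 2 values shown sits. Within the data shown here, it therefore sits at the weak end of the two values so far, without a known margin.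

The step to compound 3 is 1-(fluoromethyl)-2-methylpropyl in place of 2-(hydroxymethyl)-1-methylpropyl on a saturated chain carbon bound to two aromatic carbons. Among the measured compounds shown here, the only measured step, an at least 1.3-fold higher number from compound 1 to compound 2 (0.14 log units; that floor lies within the scatter), runs the other way in structural terms: compound 1 carries the 1-(methoxymethyl)-2-methylpropyl group, and compound 3 keeps the 2-methylpropyl branching while swapping the methoxymethyl arm for a fluoromethyl arm. That measured step was small and not beyond the scatter, so the bearing on compound 3 is weak. Compound 3 is expected to come back toward compound 1, an estimated improvement of an at least 1.2-fold lower number from compound 2 to compound 3 (0.09 log units; that floor lies within the scatter) in this assay, with a real chance of another limit. Compound 3 is estimated at 80000 nM, in a range from 30000 nM to 200000 nM.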

Compound 3, half-maximal inhibitory concentration: 39000 nM
For compound 3 the middle estimate is 2.1-fold (0.31 log units) above the measured one; low and high end bracket the measured number.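

In this assay, the 1-(fluoromethyl)-2-methylpropyl group gives the only step shown that lies beyond the scatter: an at least 2.5-fold lower number from compound 2 to compound 3 (0.40 log units; beyond the scatter). The size of that step remains a floor, because compound 2 stands at a limit and not at a number: the limit of > 100000 nM in this assay, at which 1 of the 3 values shown sits. Against the 1-(methoxymethyl)-2-methylpropyl group the reading does not separate, with a 1.8-fold lower number from compound 1 to compound 3 (0.27 log units; within the scatter), so the fluoromethyl and methoxymethyl arms cannot be told apart at this position on the saturated chain carbon bound to two aromatic carbons.

The compounds shown do not separate the exchange of the hydroxyl for fluorine from the difference in branching between the 2-(hydroxymethyl)-1-methylpropyl and 1-(fluoromethyl)-2-methylpropyl groups, as the two changes arrive together in one step. Also open, on these data alone, is how an aminomethyl arm, a carboxylic acid or a longer chain in this place would read in this assay, and whether any such side chain on the shared core would give a step clearly beyond the scatter from compound 1.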